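Replacing a Dibutylamino Group with a Methylpiperidine Ring

This account rests on a few compounds, and the source may have more. Where it says the series, first, only, none or still open, it means among the compounds named here.

Measured compounds:
Compound 1 `CCC(C)NC(=O)/C=C/c1c(/C=C/c2ccc(OC)cc2)cc(OC)cc1OC` gives 4380 nM in a functional assay on B16-F10 cells (Mus musculus) for inhibition, read by MTT assay, with a stated time of 48 h; on this read-out lower numbers stand for stronger inhibition and higher numbers for weaker inhibition.
Compound 2 `COc1ccc(/C=C/c2cc(OC)cc(OC)c2/C=C/C(=O)N2CCN(C)CC2)cc1` gives 5670 nM in this assay.
Compound 3 `CCCCN(CCCC)C(=O)/C=C/c1c(/C=C/c2ccc(OC)cc2)cc(OC)cc1OC` gives 9030 nM in this assay.

All three compounds share one core and differ only in the group attached to the amide carbonyl. Compound 3 has the highest number of the three; its gap to compound 2 is within the scatter, while its gap to compound 1 is beyond it, so compound 3 is the weakest inhibitor relative to compound 1 only.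

Compound 4 `COc1ccc(/C=C/c2cc(OC)cc(OC)c2/C=C/C(=O)N2CCCC(C)C2)cc1` is unmeasured. It differs from compound 3 as follows: 3-methylpiperidin-1-yl in place of dibutylamino on a carbonyl carbon.

Within the data shown here, two measured steps bear on this change. The step of a 2.1-fold higher number from compound 1 to compound 3 (0.31 log units; beyond the scatter) and the step of a 1.6-fold higher number from compound 2 to compound 3 (0.20 log units; within the scatter) both show that the dibutylamino group carried a somewhat higher number than a smaller or cyclic amine. Reversing that direction, a modest step downward is expected, a 1.5-fold lower number from compound 3 to compound 4 (0.18 log units; within the scatter), though a change within the scatter would not be surprising. Compound 4 is therefore expected to give about 6000 nM, with a range from 3000 nM to 12000 nM.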

Compound 4, half-maximal inhibitory concentration: 8250 nM
Compound 4: middle estimate off by 1.4-fold (0.14 log units), on the low side; the measured number falls inside the stated range.
By their numbers in this assay, from the lowest: compounds 1, 2, 4 and 3 (each within the scatter of the next, the first and the last beyond it).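

In this assay, putting 3-methylpiperidin-1-yl in place of dibutylamino on the carbonyl carbon gives a 1.1-fold lower number from compound 3 to compound 4 (0.04 log units; within the scatter) and so shows that a ring with fewer heavy atoms cannot be told apart from the open-chain group at this position. Compound 4 also stays within the scatter of the other two amides, with a 1.5-fold higher number from compound 2 to compound 4 (0.16 log units; within the scatter) and a 1.9-fold higher number from compound 1 to compound 4 (0.27 log units; within the scatter) as the two steps, so it falls in with all three and only compound 1 and compound 3 remain separated. Nothing available here gives a reason for these numbers.

Whether the place of the methyl on the ring matters remains open, as 4-methylpiperidin-1-yl and plain piperidin-1-yl do not appear among these compounds. Also open, going by these compounds, is whether morpholin-4-yl or a longer chain such as dihexylamino would stand apart from these four.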